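The source may hold more compounds than are shown below. What is called first, only, known or untested is meant among the compounds shown, and "the series" means these compounds.

Compound 1 `CC1=NC(C)=C(C(=O)OCCCN2C(=O)c3ccccc3S2(=O)=O)C(c2ccccc2C(F)(F)F)/C1=C(\O)OCC1CCCO1` is the reference of this small set; in a functional assay (aorta) with Oryctolagus cuniculus as the target (on this read-out higher numbers stand for weaker inhibition and lower numbers for stronger inhibition), compound 1 gives 3.7 nM. Compound 2 `CC1=NC(C)=C(C(=O)OCCCN2C(=O)c3ccccc3S2(=O)=O)C(c2ccccc2C(F)(F)F)/C1=C(\O)OCC1CCCCO1` carries oxan-2-yl in place of oxolan-2-yl on a saturated chain carbon bound to an oxygen on an unsaturated carbon, and in this assay compound 2 gives 1.4 nM, so that a 2.6-fold lower number from compound 1 to compound 2 (0.42 log units; beyond the scatter). Compound 3 `CC1=NC(C)=C(C(=O)OCCCN2C(=O)c3ccccc3S2(=O)=O)C(c2ccccc2Cl)/C1=C(\O)OCC1CCCO1` differs from compound 1 in its core by chloro in place of trifluoromethyl on an aromatic carbon; in this assay compound 3 gives 7.1 nM, with a 1.9-fold higher number from compound 1 to compound 3 (0.28 log units; within the scatter). Compound 4 `CC1=NC(C)=C(C(=O)OCCCN2C(=O)c3ccccc3S2(=O)=O)C(c2ccccc2Cl)/C1=C(\O)OCC1CCCCO1` is not yet measured. Relative to compound 3 it carries oxan-2-yl in place of oxolan-2-yl on a saturated chain carbon bound to an oxygen on an unsaturated carbon, the same change that separates compound 2 from compound 1, since the place is the same in both pairs. Because a 2.6-fold lower number from compound 1 to compound 2 (0.42 log units; beyond the scatter), the step in this assay is expected to read a 2.6-fold lower number from compound 3 to compound 4 (0.42 log units; beyond the scatter). On that basis compound 4 is estimated to give 2.7 nM in this assay, most likely between 1.3 nM and 5.5 nM.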

Compound 4, half-maximal inhibitory concentration: 7 nM
Compound 4: middle estimate off by 2.6-fold (0.41 log units), on the low side, outside the stated range (above it).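

In this assay, oxan-2-yl in place of oxolan-2-yl gives a 1.0-fold lower number from compound 3 to compound 4 (0.01 log units; within the scatter), and the two readings of this change do not differ beyond what the scatter allows: the same change on two cores in this assay, a 2.6-fold lower number (0.42 log units; beyond the scatter) from compound 1 to compound 2 and a 1.0-fold lower number (0.01 log units; within the scatter) from compound 3 to compound 4, 2.6-fold (0.42 log units) apart, within the scatter of two such steps

Chloro in place of trifluoromethyl gives a 5.0-fold higher number from compound 2 to compound 4 (0.70 log units; beyond the scatter), and the same holds for this change: the same change on two cores in this assay, a 1.9-fold higher number (0.28 log units; within the scatter) from compound 1 to compound 3 and a 5.0-fold higher number (0.70 log units; beyond the scatter) from compound 2 to compound 4, 2.6-fold (0.42 log units) apart, within the scatter of two such steps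

The data therefore give no ground to say that either change depends on the core, yet two pairs per change, with steps this far apart, do not show that it carries over unchanged either.

The compounds shown leave open how the read-out responds to other groups, such as an amine or a longer chain in place of oxan-2-yl, or a nitrile in place of chloro.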